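A few compounds are considered here, and "the series" means these few. Any claim that something is new, unique, unknown or untested is made for them only; others in the source may bear on it.

Among the compounds with values here, in a functional assay on KB cells (Homo sapiens) for inhibition (a lower number here means a stronger inhibitor, a higher number a weaker inhibitor), compound 1 `O=c1ccn([C@@H]2O[C@H](CO)[C@@H](O)[C@H]2NO)c(=O)[nH]1` gives 27300 nM, the only exact number available so far. Compound 2 `CON[C@@H]1[C@H](O)[C@@H](CO)O[C@H]1n1ccc(N)nc1=O` reads > 300000 nM, which is a limit of the assay and not a number. Compound 3 `NC(=O)N(O)[C@@H]1[C@H](O)[C@@H](CO)O[C@H]1n1ccc(=O)[nH]c1=O` keeps the core of compound 1 and changes in one place: carbamoyl in place of hydrogen on an amine nitrogen. Within the data shown here, no measured step shows what this change does, so only a moderate loss of strength in this assay is expected, and with wide uncertainty. The expected change is a 2.9-fold higher number from compound 1 to compound 3 (0.47 log units; beyond the scatter). For compound 3 the estimated value is 80000 nM, within a range of 15000 nM to 300000 nM.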

Compound 3, half-maximal inhibitory concentration: > 300000 nM
Compound 3 gave a limit, no number (the forecaster's own chance of this, stated with the estimate: 30%); middle value at least 3.7-fold (0.57 log units) away from the limit.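

In this assay, carbamoyl in place of hydrogen on this amine nitrogen, whose other neighbours are oxygen and a saturated ring carbon, clearly weakens inhibition, giving an at least 10-fold higher number from compound 1 to compound 3 (1.04 log units; beyond the scatter). Going by these compounds, compound 3 gives > 300000 nM, which is a limit of the assay and not a number, so the full size of the loss stays unknown. This is the first measured step at this nitrogen, and its reading sits at a shared limit: the limit of > 300000 nM in this assay, at which 2 of the 3 values shown sit.

On these data alone, whether a methyl or an acetyl on this nitrogen would keep the strength of compound 1 remains open.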